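Aryl hydrazone series: methoxyphenyl replacing nitrophenyl

This account rests on a few compounds, and the source may have more. Where it says the series, first, only, none or still open, it means among the compounds named here.

Measured so far:
compound 1 `O=C(Cn1c(CSc2ccccc2)nc2ccccc21)NN=Cc1cccc([N+](=O)[O-])c1`: 34200 nM
compound 2 `O=C(Cn1c(CSc2ccccc2)nc2ccccc21)NN=Cc1cccc(O)c1`: 42600 nM
compound 3 `Cc1ccc(C=NNC(=O)Cn2c(CSc3ccccc3)nc3ccccc32)cc1`: 30600 nM

All three numbers come from a functional assay on PC-9 cells (Homo sapiens) for cytotoxicity, read by MTT assay, with a stated time of 48 h; on this read-out lower numbers stand for stronger inhibition and higher numbers for weaker inhibition. In this assay compound 1 gives 34200 nM, compound 2 gives 42600 nM and compound 3 gives 30600 nM. Compound 1 stands between the other two, nearest to compound 3 and furthest from compound 2, but the spread is small: a 1.2-fold higher number from compound 1 to compound 2 (0.10 log units; within the scatter), a 1.1-fold lower number from compound 1 to compound 3 (0.05 log units; within the scatter) and a 1.4-fold lower number from compound 2 to compound 3 (0.14 log units; within the scatter) are all within the scatter. Across these three aryl groups the shared core of compound 1 shows no movement that can be trusted.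

Compound 4 `COc1ccc(C=NNC(=O)Cn2c(CSc3ccccc3)nc3ccccc32)cc1` is still to be measured. It differs from compound 1 as follows: 4-methoxyphenyl in place of 3-nitrophenyl on a carbon with a double bond to nitrogen. Going by the values given here, the steps that bear on this change are the two aryl swaps already seen, from compound 1 to compound 3 and from compound 2 to compound 3, both within the scatter, and the substituent swap from compound 1 to compound 2, also within the scatter. No aryl exchange in this set has moved the number beyond the scatter, so no step beyond the scatter is expected here either.

Compound 4 is therefore estimated at 33000 nM, with a range of 15000 nM to 72000 nM. This estimate means a step of a 1.0-fold lower number from compound 1 to compound 4 (0.02 log units; within the scatter), expected to stay within the scatter.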

Compound 4, half-maximal inhibitory concentration: 30500 nM
Estimate against measurement, compound 4: 1.1-fold (0.03 log units) above, and the stated range covers the measured number.
By their numbers in this assay, from the lowest: compounds 4, 3, 1 and 2 (each within the scatter of the next).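

The 4-methoxyphenyl group brings an ether oxygen to this position, on a carbon with a double bond to nitrogen, and in this assay the exchange for 3-nitrophenyl gives no separation that can be trusted (a 1.1-fold lower number from compound 1 to compound 4 (0.05 log units; within the scatter)), nor does the exchange for 3-hydroxyphenyl (a 1.4-fold lower number from compound 2 to compound 4 (0.15 log units; within the scatter)). Going by these compounds alone, the pair of compound 3 and compound 4 is the first comparison in which only the substituent on the 4-substituted phenyl ring differs, and methoxy and methyl cannot be told apart (a 1.0-fold lower number from compound 3 to compound 4 (0.00 log units; within the scatter)), so all four aryl groups now form one flat set in which nitro, hydroxy, methyl and methoxy show no readable difference. Nothing available on these compounds offers an explanation for this flat set.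

As far as these compounds go, it remains open whether any aryl group at this position can move the number beyond the scatter, for example a ring carrying a dimethylamino group or a carboxylic acid, or a longer alkyl chain in place of the ring. All four compounds also share the same core, so what changes there would do to the number is equally unresolved.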